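Cytotoxicity of Quinolyl Ureas: A Chlorophenyl Variant

A few compounds are considered here, and "the series" means these few. Any claim that something is new, unique, unknown or untested is made for them only; others in the source may bear on it.

Compound 1 `Cc1ccc(NC(=O)Nc2cc(C)nc3ccccc23)cc1` is a urea with a 4-methylphenyl group on an amide-type nitrogen. In an ADME assay on HEK293 cells (Homo sapiens) for cytotoxicity, with a stated time of 72 h (a lower number here means that less compound is needed, a higher number that more compound is needed for the effect), compound 1 gives > 25000 nM, which is a limit of the assay and not a number. Going by the values given here, its only measured neighbour, compound 2 `Cc1cc(NC(=O)Nc2ccc(C(F)(F)F)cc2)c2ccccc2n1`, gives 25000 nM in this assay. Among the compounds with values here, the single measured step, a number no higher from compound 1 to compound 2 (the limit leaves the size open), concerns a different change, and because of the limit of > 25000 nM in this assay, at which 1 of the 2 values shown sits, its size cannot be read. Compound 3 `Cc1cc(NC(=O)Nc2cccc(Cl)c2)c2ccccc2n1` differs from compound 1 by 3-chlorophenyl in place of 4-methylphenyl on an amide-type nitrogen. Within the data shown here, no measured step covers this exchange, and both known values sit at or at the edge of the range of this assay, so nothing points to a move in either direction. Compound 3 is therefore expected to give about 25000 nM in this assay, within a range from 12000 nM to 50000 nM. The step of a number no higher from compound 1 to compound 3 (the limit leaves the size open) is expected to stay within the usual scatter.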

Compound 3, half-maximal effective concentration: 21000 nM
Estimate against measurement, compound 3: 1.2-fold (0.08 log units) above; the range from low to high includes it.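

Replacing 4-methylphenyl with 3-chlorophenyl on the amide-type nitrogen gives an at least 1.1-fold lower number from compound 1 to compound 3 (0.07 log units; that floor lies within the scatter). Going by these compounds alone, this is the first measured exchange at this position that does not involve trifluoromethyl, and with it compound 3 joins compound 2 in giving a value at the edge of the measured range, so two different aryl groups now give readable numbers within the scatter of each other. How far the step truly reaches cannot be read, and the comparison with compound 1 stays one-sided because of a limit: the limit of > 25000 nM in this assay, at which 1 of the 3 values shown sits.

The compounds shown leave open whether an amine or a carboxylic acid on this phenyl ring would bring the number clearly down. They also leave open whether chlorine as 4-chlorophenyl would give the same value as 3-chlorophenyl.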